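A para-fluoro analogue of a weak histone deacetylase 8 inhibitor

A few compounds are considered here, and "the series" means these few. Any claim that something is new, unique, unknown or untested is made for them only; others in the source may bear on it.

Going by the values given here, compound 1 `O=C1NC(=O)/C(=C\c2ccc(OCC(=O)N3N=C(c4ccccc4)CC3c3ccccc3)cc2)S1` gives 20000 nM in an assay on cells for inhibition of histone deacetylase 8 (Homo sapiens), read by fluorescence, with a stated time of 30 min (a lower number here means a stronger inhibitor, a higher number a weaker inhibitor), the lower of the two numbers measured so far. Its chloro analogue, compound 2 `O=C1NC(=O)/C(=C\c2ccc(OCC(=O)N3N=C(c4ccccc4)CC3c3ccccc3Cl)cc2)S1`, gives 29000 nM, and the step of a 1.5-fold higher number from compound 1 to compound 2 (0.16 log units; within the scatter) lies within the scatter. Compound 3 `O=C1NC(=O)/C(=C\c2ccc(OCC(=O)N3N=C(c4ccccc4)CC3c3ccc(F)cc3)cc2)S1` differs from compound 1 by fluoro in place of hydrogen on an aromatic carbon. Among the compounds with values here, the only comparable step, that from compound 1 to compound 2, was within the scatter, so a step of about a 1.1-fold higher number from compound 1 to compound 3 (0.04 log units; within the scatter) is expected, with no direction beyond the scatter. For compound 3 the estimate in this assay is 22000 nM, ranging from 10000 nM to 45000 nM.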

Compound 3, half-maximal inhibitory concentration: 26000 nM
For compound 3 the middle estimate is 1.2-fold (0.07 log units) below the measured one; low and high end bracket the measured number.
By their numbers in this assay, from the lowest: compounds 1, 3 and 2 (each within the scatter of the next).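

In this assay, a second halogen on this phenyl ring, now fluoro para to a large group, gives no step beyond the scatter (a 1.3-fold higher number from compound 1 to compound 3 (0.11 log units; within the scatter)). Moving from 2-chlorophenyl to 4-fluorophenyl also stays within the scatter (a 1.1-fold lower number from compound 2 to compound 3 (0.05 log units; within the scatter)), so neither the halogen nor its place on the ring separates these three compounds.

As far as these compounds go, whether an amine or a carboxylic acid on this ring would move the number beyond the scatter remains open. Nothing available here explains the closeness of these numbers.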